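A few compounds are considered here, and "the series" means these few. Any claim that something is new, unique, unknown or untested is made for them only; others in the source may bear on it.

Values in a functional assay on HOS-TE85 cells (Homo sapiens) for inhibition, read by CCK-8 assay, with a stated time of 72 h (on this read-out lower numbers stand for stronger inhibition and higher numbers for weaker inhibition), for the measured compounds
- compound 1 `CC1SC(c2cccc(C(=O)NCCCCc3ccccc3)c2)N(c2ccc(C3CC3)cc2)C1=O` gives 191 nM
- compound 2 `C#Cc1cccc(N2C(=O)CSC2c2cccc(C(=O)NCCCCc3ccccc3)c2)c1` gives 149 nM
- compound 3 `O=C(NCCCCc1ccccc1)c1cccc(C2SCC(=O)N2c2ccccc2F)c1` gives 34.1 nM

Compound 3 has the lowest of these numbers, and its gaps to compound 1 and compound 2 both lie beyond the usual scatter. Compound 4 `O=C(NCCCCc1ccccc1)c1cccc(C2SCC(=O)N2c2ccc(C3CC3)cc2)c1` keeps the core of compound 3 and changes one group. The change is 4-cyclopropylphenyl in place of 2-fluorophenyl on an amide-type nitrogen in a ring and it puts 4-cyclopropylphenyl in place of 2-fluorophenyl on an amide-type nitrogen in a ring. Among the measured compounds shown here, one measured step touches this place: a 4.4-fold lower number from compound 2 to compound 3 (0.64 log units; beyond the scatter) on gaining 2-fluorophenyl. Compound 1 carries 4-cyclopropylphenyl on a core that is not identical and gives 191 nM within the scatter of compound 2. Losing 2-fluorophenyl is therefore expected to undo much of that gain. The expected change is a 3.8-fold higher number from compound 3 to compound 4 (0.58 log units; beyond the scatter) in this assay overall. For compound 4 the estimate is 130 nM with an expected range from 50 nM to 300 nM at its two ends.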

Compound 4, half-maximal inhibitory concentration: 217 nM
Compound 4: the middle estimate sits 1.7-fold (0.22 log units) below what was measured, and the stated range covers the measured number.
By their numbers in this assay, from the lowest: compound 3; then compounds 2, 1 and 4 (each within the scatter of the next).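

On the shared core, the group on the amide-type nitrogen in the ring clearly changes the result in this assay, with 4-cyclopropylphenyl replacing 2-fluorophenyl giving (a 6.4-fold higher number from compound 3 to compound 4 (0.80 log units; beyond the scatter)). Exchanging 3-ethynylphenyl for 4-cyclopropylphenyl at this place gives no readable difference (a 1.5-fold higher number from compound 2 to compound 4 (0.16 log units; within the scatter)). Hydrogen in place of methyl on a saturated ring carbon also gives no readable difference (a 1.1-fold higher number from compound 1 to compound 4 (0.06 log units; within the scatter)).

Plain phenyl, 2-chlorophenyl or 4-fluorophenyl at this nitrogen would help show whether the fluorine or its place on the ring goes with the lower number. No measured evidence gives a reason for these differences.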